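This account rests on a few compounds, and the source may have more. Where it says the series, first, only, none or still open, it means among the compounds named here.

Compound 1 `Nc1ccc(Nc2c(C(=O)NCc3ccc(F)cc3)nc(Br)c3cccnc23)cc1` carries a 4-aminophenyl on the nitrogen on its core. In a functional assay on MDA-MB-435 cells (Homo sapiens) for cytotoxicity, read by MTT assay, with a stated time of 72 h (a higher number here means a weaker inhibitor, a lower number a stronger inhibitor), compound 1 gives 7000 nM. Two companions share that core: compound 2 `N[C@H]1CC[C@H](Nc2c(C(=O)NCc3cccc(C(F)(F)F)c3)nc(Br)c3cccnc23)CC1`, which in this assay gives 4200 nM, and compound 3 `N[C@H]1CC[C@H](Nc2c(C(=O)NCc3ccc(Cl)cc3Cl)nc(Br)c3cccnc23)CC1`, which gives 5800 nM. The three numbers lie within the usual scatter of one another, so compound 1 stands alongside compound 2 and compound 3 rather than apart from them. For the measured compounds named here, the only step between measured compounds that differ in one place is a 1.4-fold higher number from compound 2 to compound 3 (0.14 log units; within the scatter), a change on a saturated chain carbon bound to an amide-type nitrogen, not on the nitrogen on the aromatic ring.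

Compound 4 `COC(=O)CNc1c(C(=O)NCc2ccc(F)cc2)nc(Br)c2cccnc12` differs from compound 1 at that nitrogen: (methoxycarbonyl)methyl in place of 4-aminophenyl on a nitrogen on an aromatic ring. Going by the values given here, no measured step touches this part of the molecule, and the step from compound 2 to compound 3 concerns a different group, so it gives no guide to size or direction here. Among the compounds with values here, the measured compounds show only that one change left the numbers within the scatter. With nothing bearing directly on the change, the step from compound 1 to compound 4 is expected to be a 1.1-fold higher number from compound 1 to compound 4 (0.06 log units; within the scatter), with wide uncertainty. Compound 4 is therefore estimated at 8000 nM, within a range from 2000 nM to 30000 nM.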

Compound 4, half-maximal inhibitory concentration: 10000 nM
For compound 4 the middle estimate is 1.3-fold (0.10 log units) below the measured one; low and high end bracket the measured number.
By their numbers in this assay, from the lowest: compounds 2, 3, 1 and 4 (each within the scatter of the next, the first and the last beyond it).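

In this assay, for the compounds shown here, the exchange of 4-aminophenyl for (methoxycarbonyl)methyl on the nitrogen on the aromatic ring gives a 1.4-fold higher number from compound 1 to compound 4 (0.15 log units; within the scatter) and is the first measured step at this position. For this pair, then, the six-membered aromatic ring and its amino group can give way to a chain with no ring and an ester carbonyl while the number stays within the scatter, so this position tolerates a substantial change of group without a measurable shift in this cytotoxicity read-out, at least in this one case. Nothing measured on these compounds accounts for that outcome.

As far as these compounds go, it remains open whether a carboxylic acid in place of the methyl ester, a longer chain, or a chain ending in a free amine on this nitrogen would move the number beyond the scatter. The step has also been read only with the amide side chain that compound 1 and compound 4 share, so whether it holds with the amide groups of compound 2 or compound 3 is not settled.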